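The source may report more compounds than this note shows. Statements on the series, on what has been measured and on what is new or still open speak of the compounds shown alone.

Measured so far in a functional assay on RS4-11 cells (Homo sapiens) for inhibition, read by CCK-8 assay, with a stated time of 48 h; a higher number here means a weaker inhibitor, a lower number a stronger inhibitor:

- Compound 1 `O=C(NCCNS(=O)(=O)c1sccc1-c1ccccc1Oc1ccc(O)c(O)c1)Nc1cc(Cl)cc(Cl)c1` gives 6200 nM
- Compound 2 `COc1ccc(NC(=S)NCCNS(=O)(=O)c2sccc2-c2ccc(C)cc2Oc2ccc(O)c(O)c2)cc1` gives 8300 nM
- Compound 3 `Cc1ccc(-c2ccsc2S(=O)(=O)NCCNC(=S)Nc2ccc([N+](=O)[O-])cc2)c(Oc2ccc(O)c(O)c2)c1` gives 5100 nM

On these numbers compound 3 has no separate place: its value of 5100 nM lies within the scatter of the values of compound 1 and compound 2, and the three form a single band.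

The change from compound 3 to compound 4 `Cc1ccc(-c2ccsc2S(=O)(=O)NCCNC(=O)Nc2cc(Cl)cc(Cl)c2)c(Oc2ccc(O)c(O)c2)c1` is a group of 11 heavy atoms (7 carbon, 1 nitrogen, 1 oxygen, 2 chlorine; one six-membered aromatic ring of carbon only) in place of a group of 12 heavy atoms (7 carbon, 2 nitrogen, 2 oxygen, 1 sulfur; one six-membered aromatic ring of carbon only), on an amine nitrogen and the entering group is (3,5-dichlorophenyl)carbamoyl. Going by the values given here, only one measured step touches this end of the molecule. It is a 1.6-fold lower number from compound 2 to compound 3 (0.21 log units; within the scatter) with nitro in place of methoxy on an aromatic carbon, and it covers only a small part of the present exchange.

Compound 1 already carries the (3,5-dichlorophenyl)carbamoyl group, although its core is not identical to that of compound 4. Compound 1 stands at 6200 nM in the same band as compound 3. Neither observation points in a direction, so no change beyond the scatter is expected in this assay here. The expected move is a 1.1-fold higher number from compound 3 to compound 4 (0.06 log units; within the scatter) and nothing more is anticipated. For compound 4 the estimated value is 5800 nM with 2900 nM to 11500 nM as the expected range.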

Compound 4, half-maximal inhibitory concentration: 5100 nM
Beside the measured number, compound 4's estimate is 1.1-fold (0.06 log units) above it; the measured number falls inside the stated range.
By their numbers in this assay, from the lowest: compounds 3, 4, 1 and 2 (each within the scatter of the next).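

In this assay, going by these compounds alone, putting (3,5-dichlorophenyl)carbamoyl on the amine nitrogen gives no change at the digits printed from compound 3 to compound 4 (within the scatter) and, against the group carried by compound 2, a 1.6-fold lower number from compound 2 to compound 4 (0.21 log units; within the scatter), so this end of the molecule has now taken a second kind of exchange, larger than the single nitro for methoxy swap, with the number still inside one band. Within the data shown here, the comparison with compound 1 adds the first reading of a different place, methyl in place of hydrogen on an aromatic carbon, and gives a 1.2-fold lower number from compound 1 to compound 4 (0.08 log units; within the scatter), so that change also leaves no mark beyond the scatter in this set. Nothing measured independently on these compounds speaks to these results.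

The exchange from compound 3 to compound 4 alters the linking atoms and the ring substituents together, so the contribution of each remains unresolved. All groups shown on the amine nitrogen carry an aromatic ring, and it remains open whether a group without one, such as acetyl or cyclohexylcarbamoyl, would stay in the same band.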